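Triazole thioacetohydrazones against HepG2 cells: methoxy to hydroxy

The source may hold more compounds than are shown below. What is called first, only, known or untested is meant among the compounds shown, and "the series" means these compounds.

Two compounds of the series carry numbers in a functional assay on HepG2 cells (Homo sapiens) for inhibition, read by MTT assay, with a stated time of 48 h; on this read-out lower numbers stand for stronger inhibition and higher numbers for weaker inhibition. Compound 1 `Clc1cccc(CSc2nnc(-c3ccncc3)n2-c2ccccc2)c1` gives 11200 nM, and compound 2 `COc1ccc(/C=N/NC(=O)CSc2nnc(-c3ccncc3)n2-c2ccccc2)cc1` gives 27100 nM; compound 2 therefore holds the higher of the two numbers, with the gap to compound 1 lying beyond the usual scatter. Compound 3 `O=C(CSc1nnc(-c2ccncc2)n1-c1ccccc1)N/N=C/c1ccccc1O` is not yet measured; it differs from compound 2 by 2-hydroxyphenyl in place of 4-methoxyphenyl on a carbon with a double bond to nitrogen. Nothing in the measured pair bears on such a change, so no step beyond the scatter is expected from compound 2 to compound 3 in this assay, the expected step being a 1.1-fold lower number from compound 2 to compound 3 (0.04 log units; within the scatter). Compound 3 is estimated at 25000 nM, within 10000 nM to 62000 nM.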

Compound 3, half-maximal inhibitory concentration: 11300 nM
Beside the measured number, compound 3's estimate is 2.2-fold (0.34 log units) above it, within the range that was stated.
By their numbers in this assay, from the lowest: compounds 1 and 3 (each within the scatter of the next); then compound 2.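

In this assay, going by these compounds alone, the group on the carbon with a double bond to nitrogen does matter: 2-hydroxyphenyl in place of 4-methoxyphenyl gives a 2.4-fold lower number from compound 2 to compound 3 (0.38 log units; beyond the scatter) as a modest step, which the earlier compounds could not show. Both the group and its place on the ring change here, so the step belongs to the pair as a whole. No measurement shown gives a reason for this step. As far as these compounds go, whether it follows the hydroxy group or its place remains open, as 4-hydroxyphenyl or 2-methoxyphenyl would separate the two. From the compounds shown here alone, how an amine or a carboxylic acid on this ring would read is also open.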